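Urotensin-2 receptor efficacy: removing the dimethylamino group

A few compounds are considered here, and "the series" means these few. Any claim that something is new, unique, unknown or untested is made for them only; others in the source may bear on it.

Measured so far:
- compound 1 `Cc1ccccc1C(=O)NC(CCN(C)C)c1ccc(Cl)cc1` — 175%
- compound 2 `CN(C)CCC(NC(=O)c1ccc(N(C)C)cc1)c1ccc(Cl)cc1` — 150%

In an assay on NIH3T3 cells with Urotensin-2 receptor (Homo sapiens) as the target (on this read-out lower numbers stand for smaller maximal responses and higher numbers for larger maximal responses), compound 1 reaches 175%. Compound 2 gives 150% in this assay, the lower of the two numbers, standing a gap below compound 1 that lies beyond the usual scatter of repeated measurements. Within the data shown here, no step between two measured compounds differing in a single place is available, so the pair gives only its two values.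

Compound 3 `CN(C)CCC(NC(=O)c1ccccc1)c1ccc(Cl)cc1` is not yet measured in this assay. Its change from compound 2 is hydrogen in place of dimethylamino on an aromatic carbon, on an aromatic carbon of a six-membered aromatic ring of carbon only.

Among the measured compounds shown here, with no single-place step to lean on, the expectation is a step from compound 2 to compound 3 of a number 10 percentage points higher from compound 2 to compound 3 (within the scatter), a modest rise that may not exceed the scatter. Compound 3 is estimated to reach 160%, within a range from 120% to 200%.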

Compound 3, largest response reached (reported as efficacy), in percent of the reference or control that the assay uses: 158%
Compound 3: the middle estimate sits 2 percentage points above what was measured; low and high end bracket the measured number.
By their numbers in this assay, from the lowest: compounds 2 and 3 (each within the scatter of the next); then compound 1.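

In this assay, hydrogen in place of dimethylamino on an aromatic carbon, para to a large group, gives a number 8 percentage points higher from compound 2 to compound 3 (within the scatter) and so leaves the read-out within the scatter: at this position, the maximal response does not depend on keeping dimethylamino. Hydrogen in place of methyl on an aromatic carbon instead gives a number 17 percentage points lower from compound 1 to compound 3 (beyond the scatter) and is the only one of these two steps beyond the scatter. No supporting data bear on why the two steps differ.

Open, on these data alone, is what a methoxy group, a primary amine or a carboxylic acid would give para to a large group on the same ring. Also open, as far as these compounds go, is whether ethyl or chlorine in the place of the methyl of compound 1 would hold the higher response.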